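Methoxy for Bromo on a Shared Benzimidazole-Pyrazole Core

A few compounds are considered here, and "the series" means these few. Any claim that something is new, unique, unknown or untested is made for them only; others in the source may bear on it.

Measured compounds:
compound 1, `Brc1ccc2[nH]c(-c3cn(-c4ccccc4)nc3-c3ccccc3)nc2c1`, gives 1810 nM in a functional assay on A549 cells (Homo sapiens) for antiproliferative activity, read by MTT assay, with a stated time of 48 h; on this read-out lower numbers stand for stronger inhibition and higher numbers for weaker inhibition
compound 2, `COc1ccc2[nH]c(-c3cn(-c4ccccc4)nc3-c3ccccc3)nc2c1`, gives 1230 nM in this assay
compound 3, `Clc1ccc(-c2nn(-c3ccccc3)cc2-c2nc3cc(Br)ccc3[nH]2)cc1`, gives 2170 nM in this assay

Compound 1 and compound 2 differ in one place: methoxy in place of bromo on an aromatic carbon. In this assay this change gives a 1.5-fold lower number from compound 1 to compound 2 (0.17 log units; within the scatter), so the two compounds cannot be told apart on this read-out. Compound 3 carries a different core than compound 1; the difference is chloro in place of hydrogen on an aromatic carbon, and in this assay it gives a 1.2-fold higher number from compound 1 to compound 3 (0.08 log units; within the scatter). Compound 3 and compound 2 are not linked by a single change; their two values lie within the scatter of each other.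

Compound 4, `COc1ccc2[nH]c(-c3cn(-c4ccccc4)nc3-c3ccc(Cl)cc3)nc2c1`, has not yet been measured. It differs from compound 3 in the same way that compound 2 differs from compound 1: methoxy in place of bromo on an aromatic carbon. The place of the change is described in the same words in both pairs, so this is the same change made on the core of compound 3 rather than on the core of compound 1.

Among the measured compounds shown here, the only guide to what compound 4 should give is the step from compound 1 to compound 2, a 1.5-fold lower number from compound 1 to compound 2 (0.17 log units; within the scatter), which was within the scatter. On that basis the step from compound 3 to compound 4 is expected to be a 1.5-fold lower number from compound 3 to compound 4 (0.18 log units; within the scatter) in this assay. Compound 4 is therefore estimated to give 1450 nM in this assay, with a plausible range from 700 nM to 3000 nM. For the measured compounds named here, the one precedent for this change makes a large move in either direction unlikely, but a single step is a thin basis for the expectation.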

Compound 4, half-maximal inhibitory concentration: 2420 nM
Compound 4: middle estimate off by 1.7-fold (0.22 log units), on the low side, within the range that was stated.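

In this assay, methoxy in place of bromo on the core of compound 3 gives a 1.1-fold higher number from compound 3 to compound 4 (0.05 log units; within the scatter), and this step cannot be told apart from the one seen earlier on the core of compound 1: the same change on two cores in this assay, a 1.5-fold lower number (0.17 log units; within the scatter) from compound 1 to compound 2 and a 1.1-fold higher number (0.05 log units; within the scatter) from compound 3 to compound 4, 1.6-fold (0.22 log units) apart, within the scatter of two such steps The chloro in place of hydrogen gives a 2.0-fold higher number from compound 2 to compound 4 (0.29 log units; within the scatter) on the methoxy-bearing core, and this step also agrees with its earlier counterpart: the same change on two cores in this assay, a 1.2-fold higher number (0.08 log units; within the scatter) from compound 1 to compound 3 and a 2.0-fold higher number (0.29 log units; within the scatter) from compound 2 to compound 4, 1.6-fold (0.22 log units) apart, within the scatter of two such steps Across these four compounds, neither change moves the number beyond the scatter on either core, so the result shows that the small steps carry over, but it cannot show that a change with a real effect would transfer in the same way, and it rests on just two cores and one cell line.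

From the compounds shown here alone, it remains open whether an amine or a carboxylic acid on that aromatic carbon, or a longer chain such as butoxy in place of methoxy, would give a step beyond the scatter. Going by these compounds, it is also open whether the agreement between cores would hold for a group such as nitrile or trifluoromethyl in place of the chloro.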